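This account rests on a few compounds, and the source may have more. Where it says the series, first, only, none or still open, it means among the compounds named here.

Going by the values given here, compound 1, with the structure `C/C=C/C(=O)Nc1ccc(CCCCCC)cc1`, is one of two compounds measured in an assay on isolated protein for displacement of a labelled ligand from thyroid hormone receptor alpha (Homo sapiens), read by fluorescence polarization; a lower number here means a stronger inhibitor, a higher number a weaker inhibitor. In this assay compound 1 reaches only a limit, > 100000 nM, and no number. Compound 2, with the structure `C#CC(=O)Nc1ccc(CCCCCC)cc1`, gives in this assay a value of 68900 nM. The step between them, an at least 1.4-fold lower number from compound 1 to compound 2 (0.16 log units; that floor lies within the scatter), is therefore only a floor; since one of the two values sits at the limit (the limit of > 100000 nM in this assay, at which 1 of the 2 values shown sits), the true size of that step is not known. Among the compounds with values here, compound 2 thus stands as the only compound with an actual number in this assay, and that number is itself a weak one.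

Compound 3, with the structure `C#CC(=O)Oc1ccc(CCCCCC)cc1`, differs from compound 2 in one place: (ethynylcarbonyl)oxy in place of (ethynylcarbonyl)amino on an aromatic carbon. Within the data shown here, the single measured step does not bear on this change, since it concerns the group on the carbonyl carbon and not the atom that joins the acyl group to the ring. Among the measured compounds shown here, with no step to guide it, compound 3 is expected to stay close to compound 2, with a change of a 1.2-fold higher number from compound 2 to compound 3 (0.09 log units; within the scatter) that lies within the scatter. The estimate for compound 3 in this assay is therefore 85000 nM, with a range from 30000 nM to 250000 nM.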

Compound 3, half-maximal inhibitory concentration: 16700 nM
The estimate for compound 3 lay 5.1-fold (0.71 log units) above the measured number; the measured number lies below the stated range.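

In this assay, the link that joins the acyl group to the ring matters at this aromatic carbon: exchanging (ethynylcarbonyl)amino for (ethynylcarbonyl)oxy gives a 4.1-fold lower number from compound 2 to compound 3 (0.62 log units; beyond the scatter). Going by these compounds alone, the earlier step concerned only the group on the carbonyl carbon, so this is the first sign that the other side of the carbonyl also moves the number. The two groups have the same count of heavy atoms and differ in their hydrogen-bond donors and acceptors, but the pair cannot show which of these differences, if any, lies behind the step. The wider step, an at least 5.9-fold lower number from compound 1 to compound 3 (0.77 log units; beyond the scatter), changes both sides of the carbonyl and remains only a floor, because compound 1 stands at a limit and not at a number: the limit of > 100000 nM in this assay, at which 1 of the 3 values shown sits.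

The compounds shown leave open whether the oxygen link would give a similar step with the prop-1-en-1-yl group on the carbonyl carbon, and so whether the two changes add up. Also open, going by these compounds, is how a sulfur atom or a methylated nitrogen in that link, or a longer chain in place of the group of 6 heavy atoms, would read in this assay.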